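This account rests on a few compounds, and the source may have more. Where it says the series, first, only, none or still open, it means among the compounds named here.

Working notes on the series. Compound 1 `C=CC1=C(C(=O)NCC(C)C)C(c2ccc(F)cc2)OC1` carries an isobutyl group on the amide nitrogen. In a functional assay on SW480 cells (Homo sapiens) for cytotoxicity, read by MTT assay, with a stated time of 24 h (on this read-out higher numbers stand for weaker inhibition and lower numbers for stronger inhibition), compound 1 gives > 100000 nM, which is a limit of the assay and not a number. Compound 2 `C=CC1=C(C(=O)Nc2ccccc2OC)C(c2ccc(Cl)c(Cl)c2)OC1` is the other measured member. In this assay compound 2 gives > 100000 nM, again a limit rather than a number. Where compound 1 stands can only be said in terms of that limit: the limit of > 100000 nM in this assay, at which 2 of the 2 values shown sit, so no ordering among the measured compounds can be drawn. Compound 3 `C=CC1=C(C(=O)Nc2cccc(C)c2)C(c2ccc(F)cc2)OC1` is not yet measured. It differs from compound 1 by 3-methylphenyl in place of isobutyl on an amide-type nitrogen. Going by the values given here, no step between measured compounds differing in one place is available, so the size of the move from isobutyl to 3-methylphenyl cannot be read from a measured pair; the only guide is that both measured values sit at the limit. The expected step that the limit leaves unreadable from compound 1 to compound 3 is none beyond the scatter, and compound 3 is expected most likely to show only a limit again. For compound 3 the estimate in this assay is 150000 nM, with a range from 50000 nM to 500000 nM.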

Compound 3, half-maximal inhibitory concentration: > 100000 nM
Compound 3: no number, only a limit; the forecaster's own chance of this, stated with the estimate: 75%; the middle value does not contradict the limit.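

No step can be read between compound 1 and compound 3 in this assay, and the compounds shown all give the same reading: the limit of > 100000 nM in this assay, at which 3 of the 3 values shown sit.

The compounds shown leave open whether any member of the series gives a measurable number in this assay, and what size a change on the amide nitrogen would then have.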